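The compounds below may be only part of what the source reports. "The series", "measured", "known", "first", "only" and "open" are said of these compounds alone.

Measured so far in an ADME assay on HEK293 cells (Homo sapiens) for cytotoxicity, read by luminescence, with a stated time of 72 h; a lower number here means that less compound is needed, a higher number that more compound is needed for the effect:
compound 1 `CCOC(=O)c1c(-c2ccccc2)[nH]c2cc(OC)ccc2c1=O` gives > 22000 nM, a limit of the assay.
compound 2 `CCOC(=O)c1c(-c2cccc(-c3ccccc3)c2)[nH]c2cc(OC)ccc2c1=O` gives > 22000 nM, a limit of the assay.
compound 3 `CCOC(=O)c1c(-c2cccc(Cl)c2)[nH]c2cc(OC)ccc2c1=O` gives > 22000 nM, a limit of the assay.

Compound 2 stands only at a limit in this assay, and the two further values shown are limits as well, so nothing in the set is a read number. The measured steps are a step that the two limits leave unreadable from compound 1 to compound 2, a step that the two limits leave unreadable from compound 1 to compound 3 and a step that the two limits leave unreadable from compound 2 to compound 3; none can be read in size, so they give no scale for the next change. Compound 4 `CCOC(=O)c1c(-c2cccc(NC(C)=O)c2)[nH]c2cc(OC)ccc2c1=O` is to be measured in this assay; its difference from compound 2 is acetamido in place of phenyl on an aromatic carbon. Within the data shown here, the nearest precedent is a step that the two limits leave unreadable from compound 2 to compound 3, also a replacement of the phenyl, and it too ended at the limit. Because every value shown sits at the limit of > 22000 nM in this assay, at which 3 of the 3 values shown sit, the expected step is a step that the limit leaves unreadable from compound 2 to compound 4, none beyond the scatter. Compound 4 is therefore estimated at about 40000 nM, within 15000 nM to 150000 nM, most likely reported again as a limit.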

Compound 4, half-maximal effective concentration: > 22000 nM
Compound 4 was reported as a limit; the forecaster's own chance of this, stated with the estimate: 85%; the middle value lies beyond the limit too.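

In this assay, no step from compound 1, compound 2 or compound 3 to compound 4 can be read in size, because all four values are limits: the limit of > 22000 nM in this assay, at which 4 of the 4 values shown sit.

From the compounds shown here alone, what stays open is at what concentration, if any, these compounds reach the half-maximal effect in this assay, and whether phenyl, chloro, acetamido or hydrogen on the aromatic carbon makes any difference there.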